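The source may hold more compounds than are shown below. What is called first, only, known or untested is meant among the compounds shown, and "the series" means these compounds.

In a physicochemical assay for solubility, read by HPLC, in phosphate buffer, measured as kinetic solubility, at pH 7.4 (a lower number here means a less soluble compound, a higher number a more soluble compound), compound 1 `CCOC(=O)c1cc(-c2ccc(F)cc2)n(-c2ccc(S(N)(=O)=O)cc2)c1C` gives 12600 nM, compound 2 `CCOC(=O)c1cc(-c2ccc(F)cc2)n(-c2ccc(S(N)(=O)=O)cc2)c1` gives 36400 nM, and compound 3 `CCOC(=O)c1cc(-c2ccc(Cl)cc2)n(-c2ccc(S(N)(=O)=O)cc2)c1N` gives 4400 nM, the lowest of these three numbers. The next compound, compound 4 `CCOC(=O)c1cc(-c2ccc(F)cc2)n(-c2ccc(S(N)(=O)=O)cc2)c1N`, has not yet been measured. It departs from compound 3 by a single change: fluoro in place of chloro on an aromatic carbon. Put simply, the 4-chlorophenyl of compound 3 becomes a 4-fluorophenyl in compound 4.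

Among the measured compounds shown here, no measured step makes this exchange. For the measured compounds named here, the only step available is a 2.9-fold higher number from compound 1 to compound 2 (0.46 log units; beyond the scatter), a modest one, and it involves a different change, so it offers only a rough yardstick of size. Compound 1 at 12600 nM and compound 2 at 36400 nM both carry the 4-fluorophenyl and both stand above compound 3, but each also differs from compound 3 in another place, so their values cannot isolate the halogen. A small upward step is therefore expected, no larger than the modest one already seen and perhaps not clear of the usual scatter. The estimate amounts to an expected 1.8-fold higher number from compound 3 to compound 4 (0.26 log units; within the scatter). Compound 4 is expected at about 8000 nM, with an estimated range of 3500 nM to 18000 nM.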

Compound 4, solubility: 7500 nM
Compound 4: middle estimate off by 1.1-fold (0.03 log units), on the high side; the measured number falls inside the stated range.
By their numbers in this assay, from the lowest: compounds 3, 4 and 1 (each within the scatter of the next, the first and the last beyond it); then compound 2.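

In this assay, among the compounds shown here, the exchange of 4-chlorophenyl for 4-fluorophenyl gives the first reading at this halogen place, a 1.7-fold higher number from compound 3 to compound 4 (0.23 log units; within the scatter), so chloro and fluoro cannot be told apart here in the setting of the amino compounds. At the aromatic carbon that holds amino in compound 4, the new steps add to the earlier comparison of methyl and hydrogen: amino in place of hydrogen gives a 4.9-fold lower number from compound 2 to compound 4 (0.69 log units; beyond the scatter), whereas amino in place of methyl gives a 1.7-fold lower number from compound 1 to compound 4 (0.23 log units; within the scatter), so hydrogen stands clear of both groups while amino and methyl cannot be separated. Nothing available explains any of these steps.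

Going by these compounds, it remains open whether bromo or methoxy in place of the halogen would also stay within the scatter of chloro and fluoro, and whether hydroxyl or dimethylamino at the aromatic carbon would read like amino and methyl or like hydrogen. The ethyl ester is common to all of these compounds, so how a carboxylic acid or an amide in its place would read also remains unknown.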